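The source may hold more compounds than are shown below. What is called first, only, known or untested is meant among the compounds shown, and "the series" means these compounds.

Of the compounds shown here, three have been measured in a functional assay on NCI-H460 cells (Homo sapiens) for antiproliferative activity, read by sulforhodamine B assay, with a stated time of 48 h; a lower number here means a stronger inhibitor of growth, a higher number a weaker inhibitor of growth.

Compound 1, `COc1ccc2cc(CO)oc(=O)c2c1`, gives 93.2 ug/mL.
Compound 2, `COc1ccc2cc(CCCO)oc(=O)c2c1`, gives 29.1 ug/mL.
Compound 3, `COc1ccc2c(c1)C(=O)OC(CO)C2`, gives only a limit of the assay, >= 250 ug/mL.

Compound 1 and compound 2 share a core and differ in one place: 2-hydroxyethyl in place of hydroxy on a saturated chain carbon bound to an aromatic carbon. That change made a 3.2-fold lower number from compound 1 to compound 2 (0.51 log units; beyond the scatter). Compound 3 has a different core, and the difference between the two cores is not broken down here.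

The unmeasured compound 4, `COc1ccc2c(c1)C(=O)OC(CCCO)C2`, stands to compound 3 as compound 2 stands to compound 1: 2-hydroxyethyl in place of hydroxy on a saturated chain carbon bound to a saturated ring carbon. The chain that enters is the same, but its place is not the same word for word, on a saturated chain carbon bound to a saturated ring carbon rather than to an aromatic carbon, so this is the same kind of change, not the same change.

For compound 3 the assay gave no number, because of the limit of >= 250 ug/mL in this assay, at which 1 of the 3 values shown sits, so the step to compound 4 cannot be set against the earlier one with the same confidence. The expected step is an at least 1.6-fold lower number from compound 3 to compound 4 (0.22 log units; that floor lies within the scatter), assuming the same kind of change pulls in the same direction as in this assay for compound 1 and compound 2. Compound 4 is estimated at 150 ug/mL, likely between 50 ug/mL and 400 ug/mL.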

Compound 4, concentration for 50% growth inhibition: 136 ug/mL
For compound 4 the middle estimate is 1.1-fold (0.04 log units) above the measured one, and the stated range covers the measured number.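

In this assay, replacing hydroxymethyl with 3-hydroxypropyl on the core of compound 3 gives an at least 1.8-fold lower number from compound 3 to compound 4 (0.26 log units; that floor lies within the scatter), which fits the direction seen on the core of compound 1 but does not fix a size. From the compounds shown here alone, compound 3 stands at >= 250 ug/mL, which is a limit of the assay and not a number, so the true size of this step stays unknown. Set side by side, the two cores are consistent with the change carrying over in direction, but they do not show that it carries over with the same size: the same change on two cores in this assay, a 3.2-fold lower number (0.51 log units; beyond the scatter) from compound 1 to compound 2 and an at least 1.8-fold lower number (0.26 log units; that floor lies within the scatter) from compound 3 to compound 4; the limit leaves it open whether they differ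

The compounds shown leave open whether a longer chain than 3-hydroxypropyl, or an amine or a carboxylic acid in place of the hydroxy, would lower the number further on either core. Going by these compounds, with hydroxymethyl and 3-hydroxypropyl as the only chains here, how the number follows chain length also stays unknown, as does the effect of this change on any third core.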